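A methoxy step on compound 3

The source may report more compounds than this note shows. Statements on the series, on what has been measured and on what is new or still open speak of the compounds shown alone.

Measured in an ADME assay on THP-1 cells (Homo sapiens) for cytotoxicity, read by flow cytometry and propidium iodide staining, with a stated time of 72 h; on this read-out lower numbers stand for stronger inhibition and higher numbers for weaker inhibition:
- compound 1 `CC(=O)Nc1ccc2oc(-c3ccccc3)cc(=O)c2c1`: 97000 nM
- compound 2 `Nc1ccc2oc(-c3ccccc3F)cc(=O)c2c1`: 44000 nM
- compound 3 `CC(=O)Nc1ccc2oc(-c3ccccc3)c(O)c(=O)c2c1`: 36000 nM

Among these three, compound 3 at 36000 nM and compound 2 at 44000 nM lie within the usual scatter of each other, while compound 1 stands apart at 97000 nM. The next compound is compound 4 `COc1cccc(-c2oc3ccc(NC(C)=O)cc3c(=O)c2O)c1`, which has not yet been measured. It differs from compound 3 by methoxy in place of hydrogen on an aromatic carbon, turning phenyl into 3-methoxyphenyl. Among the measured compounds shown here, only one measured step bears on this change: a 2.7-fold lower number from compound 1 to compound 3 (0.43 log units; beyond the scatter). That step also places a new group on an aromatic carbon, but the group is hydroxy and it sits elsewhere on the molecule. For the measured compounds named here, no measured pair shows what methoxy does in this assay, so neither direction can be favoured, and no change beyond the scatter is expected. The expected step is a 1.1-fold lower number from compound 3 to compound 4 (0.02 log units; within the scatter). For compound 4 the estimated value is 34000 nM, with an expected range from 15000 nM to 80000 nM.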

Compound 4, half-maximal inhibitory concentration: 50000 nM
Beside the measured number, compound 4's estimate is 1.5-fold (0.17 log units) below it; the range from low to high includes it.
By their numbers in this assay, from the lowest: compounds 3, 2, 4 and 1 (each within the scatter of the next, the first and the last beyond it).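

In this assay, among the compounds shown here, the step of a 1.4-fold higher number from compound 3 to compound 4 (0.14 log units; within the scatter) gives the first reading of a change on the phenyl ring of this series: 3-methoxyphenyl in place of phenyl leaves the number where compound 3 had it, as far as this read-out can tell. For the compounds shown here, the only step known before, a 2.7-fold lower number from compound 1 to compound 3 (0.43 log units; beyond the scatter), placed hydroxy elsewhere on the molecule and lay beyond the scatter, whereas methoxy at this place, meta to a large group, does not. Nothing measured here gives a reason for this result.

The compounds shown leave open whether an amine, a hydroxy or a longer ether chain such as ethoxy at this same place would also stay within the scatter. They also leave open how methoxy behaves on other carbons of this ring, or on a core without the hydroxy that compound 3 carries.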